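Chloro to hydrogen on the aromatic ring of compound 2

The source may hold more compounds than are shown below. What is called first, only, known or untested is meant among the compounds shown, and "the series" means these compounds.

Two compounds of this series have numbers in an in vitro assay on SH-SY5Y cells for displacement of a labelled ligand from Neuronal acetylcholine receptor; alpha3/beta4 (Homo sapiens); a higher number here means a weaker inhibitor, a lower number a stronger inhibitor. Compound 1 `C1=C(c2cccnc2)C[C@H]2CNC[C@@H]1C2` gives 4 nM in this assay. Compound 2 `Clc1cncc(C2=CC3CNCC(C2)C3)c1` gives 40 nM in this assay, the higher of the two numbers; the gap to compound 1 lies beyond the scatter of repeated measurements.

Compound 3 `C1=C(c2cccnc2)CC2CNCC1C2` has not been measured. Relative to compound 2 it carries hydrogen in place of chloro on an aromatic carbon. Among the measured compounds shown here, no step between measured compounds with this exact change is available, so the direction can only be inferred from the two values above.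

Compound 3 is expected to give a lower number than compound 2, with an estimated step of an 8.0-fold lower number from compound 2 to compound 3 (0.90 log units; beyond the scatter) in this assay. The estimate for compound 3 is 5 nM, within a range of 2 nM to 15 nM, anchored on compound 1 giving 4 nM as the stronger value of the pair.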

Compound 3, inhibition constant: 12 nM
Beside the measured number, compound 3's estimate is 2.4-fold (0.38 log units) below it; the measured number falls inside the stated range.
By their numbers in this assay, from the lowest: compound 1; then compound 3; then compound 2.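

Hydrogen in place of chloro on an aromatic carbon, two atoms from the ring nitrogen, can now be read directly in this assay, and it gives a 3.3-fold lower number from compound 2 to compound 3 (0.52 log units; beyond the scatter). The chloro is therefore not needed at this position for a low number in this assay, and the change accounts for only part of the gap between compound 1 and compound 2. The rest of that gap has a second step alongside it, a 3.0-fold higher number from compound 1 to compound 3 (0.48 log units; beyond the scatter), between two compounds with the same atoms and bonds, and the only difference there is in how they are drawn: the fact that one of compounds 1 and 3 is drawn with a defined configuration and the other without, at the place where they differ

From the compounds shown here alone, what the undefined drawing of compound 3 stands for remains open, and so does the size of the chloro step on the defined configuration of compound 1. Also open, going by these compounds, is how a fluoro, a methoxy or an amine at this aromatic carbon would compare with chloro and hydrogen.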